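Series notes: methoxy for chloro on the aryl substituent

A few compounds are considered here, and "the series" means these few. Any claim that something is new, unique, unknown or untested is made for them only; others in the source may bear on it.

Measured in an assay for binding affinity to dual specificity mitogen-activated protein kinase kinase 4 (Homo sapiens), read by KINOMEscan, tested at 100 nM; a higher number here means a weaker effect of the compound at the concentration tested, a lower number a stronger effect:
- compound 1, `CCCS(=O)(=O)Nc1ccc(F)c(C(=O)c2n[nH]c3ncc(-c4ccccc4)cc23)c1F`, gives 2.4%
- compound 2, `CCCS(=O)(=O)Nc1ccc(F)c(C(=O)c2n[nH]c3ncc(-c4ccc(Cl)cc4Cl)cc23)c1F`, gives 22%

Compound 2 stands highest of the two numbers, its nearest neighbour being compound 1 at a number 19.6 percentage points higher from compound 1 to compound 2 (beyond the scatter). Compound 3, `CCCS(=O)(=O)Nc1ccc(F)c(C(=O)c2n[nH]c3ncc(-c4ccc(OC)cc4Cl)cc23)c1F`, is not yet measured. Its change from compound 2 is methoxy in place of chloro on an aromatic carbon. Within the data shown here, only the step from compound 1 to compound 2 bears on it, and that step was modest in the upward direction. Taking away one chloro is expected to move the number part of the way back. Compound 3 is therefore estimated at 12%, with a range from 2% to 35%. The expected step is a number 10 percentage points lower from compound 2 to compound 3 (within the scatter).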

Compound 3, a percentage reported as activity, at one concentration (the size of the read-out at that concentration, not a potency): 5.3%
Beside the measured number, compound 3's estimate is 6.7 percentage points above it; measured number inside the range.
By their numbers in this assay, from the lowest: compounds 1 and 3 (each within the scatter of the next); then compound 2.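

Working in this assay, methoxy in place of chloro on the aromatic carbon para to a large group gives a number 16.7 percentage points lower from compound 2 to compound 3 (beyond the scatter) and so shows that the number at this position depends on which group sits there. With 2-chloro-4-methoxyphenyl in place of phenyl, the step is a number 2.9 percentage points higher from compound 1 to compound 3 (within the scatter) and shows that this substitution pattern can leave the number within the scatter of the unsubstituted phenyl. No evidence here explains the difference between chloro and methoxy. Still open, from the compounds shown here alone, is how an amine or a longer alkoxy chain would read at this position. Also open, going by these compounds, is what the remaining chloro contributes without methoxy present.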